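Pyridin-2-yl in Place of Phenyl, Tried Twice

The source may hold more compounds than are shown below. What is called first, only, known or untested is meant among the compounds shown, and "the series" means these compounds.

Compound 1 `Cn1nc(N)c2c(=O)[nH]c(-c3ccccc3)cc21` and compound 2 `Cn1nc(N)c2c(=O)[nH]c(-c3ccccn3)cc21` share one core and differ in a single place: pyridin-2-yl in place of phenyl on an aromatic carbon. In an assay on isolated protein for inhibition of RAC-alpha serine/threonine-protein kinase (Homo sapiens), read by mobility shift assay, tested at 30 uM (a higher number here means more inhibition at the concentration tested (going by the name of the read-out), a lower number less inhibition), compound 1 gives 8%, and compound 2 gives 7%, so the change made a number 1 percentage points lower from compound 1 to compound 2 (within the scatter). Both numbers are low, meaning that neither compound blocks much of the enzyme at the concentration tested.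

Compound 3 `Nc1c2c(=O)[nH]c(-c3ccccc3)cc2nn1-c1ccccc1` is built on a different core; the difference between the two cores is not broken down here. In this assay compound 3 gives -2%, which also lies within the scatter of the values of compound 1 and compound 2.

Compound 4 `Nc1c2c(=O)[nH]c(-c3ccccn3)cc2nn1-c1ccccc1` has not been measured. It stands to compound 3 as compound 2 stands to compound 1: pyridin-2-yl in place of phenyl on an aromatic carbon, at a place described in the same words, so it is the same change on a second core. Because the step of a number 1 percentage points lower from compound 1 to compound 2 (within the scatter) stayed within the scatter, compound 4 is expected to move only a number 2 percentage points higher from compound 3 to compound 4 (within the scatter) from compound 3. Compound 4 is therefore estimated at 0%, with a likely range from -10% to 10%.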

Compound 4, a percentage reported as inhibition, at one concentration (the size of the read-out at that concentration, not a potency): 4%
Beside the measured number, compound 4's estimate is 4 percentage points below it; measured number inside the range.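

In this assay, pyridin-2-yl in place of phenyl on an aromatic carbon of the second core gives a number 6 percentage points higher from compound 3 to compound 4 (within the scatter), so this step, like the one on the first core, is too small to read as a real change. The two steps can be treated as the same within the noise of the measurement: the same change on two cores in this assay, a number 1 percentage points lower (within the scatter) from compound 1 to compound 2 and a number 6 percentage points higher (within the scatter) from compound 3 to compound 4, 7 percentage points apart, within the scatter of two such steps. This shows that the swap left the read-out about where it was on both cores, but it does not show that the change would carry over in the same way to a compound that blocks the enzyme strongly, since all four compounds inhibit it only weakly at the concentration tested.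

The compounds shown leave open whether any group at this place could raise the inhibition clearly above the scatter, for example a phenyl ring carrying an amine or a carboxylic acid, or a longer chain in place of the ring. They also leave open how pyridin-3-yl would behave at this place.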